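This account rests on a few compounds, and the source may have more. Where it says the series, first, only, none or still open, it means among the compounds named here.

Values in a functional assay on RAW264.7 cells (Mus musculus) for inhibition, read by Griess assay, with stated times of 1 h and 24 h; a lower number here means a stronger inhibitor, a higher number a weaker inhibitor:
- Compound 1 `CCCCOc1ccc(C(O)C2OC(=O)c3c(OC)cc(OC)cc32)cc1`: 1800 nM
- Compound 2 `CCOCCOc1ccc(C(O)C2OC(=O)c3c(OC)cc(OC)cc32)cc1`: > 10000 nM, a limit of the assay and not a number
- Compound 3 `C=CCCOc1ccc(C(O)C2OC(=O)c3c(OC)cc(OC)cc32)cc1`: 1330 nM

Compound 3 holds one of the two actual numbers in the series, and its value lies within the scatter of that of compound 1, as a 1.4-fold lower number from compound 1 to compound 3 (0.13 log units; within the scatter) shows. The next structure is compound 4 `COc1cc(OC)c2c(c1)C(C(O)c1ccc(OCc3ccc(C#N)cc3)cc1)OC2=O`, which carries 4-cyanophenyl in place of allyl on a saturated chain carbon bound to an oxygen on an aromatic ring.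

All three measured steps concern this same chain end, and they differ widely in size. One is small, a 1.4-fold lower number from compound 1 to compound 3 (0.13 log units; within the scatter). The other two are large, an at least 5.5-fold higher number from compound 1 to compound 2 (0.74 log units; beyond the scatter) and an at least 7.5-fold lower number from compound 2 to compound 3 (0.87 log units; beyond the scatter). Both large steps touch compound 2 and are bounds only, because of the limit of > 10000 nM in this assay, at which 1 of the 3 values shown sits. Among the measured compounds shown here, no measured compound has an aromatic ring in this chain, so these steps guide the new change only loosely. Since the chain end tolerated one change in a 1.4-fold lower number from compound 1 to compound 3 (0.13 log units; within the scatter) but not the other in an at least 7.5-fold lower number from compound 2 to compound 3 (0.87 log units; beyond the scatter), a small move toward a higher number is expected, with wide uncertainty: a 1.9-fold higher number from compound 3 to compound 4 (0.27 log units; within the scatter). The estimate for compound 4 is 2500 nM, with an expected range from 700 nM to 9000 nM.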

Compound 4, half-maximal inhibitory concentration: 7360 nM
The estimate for compound 4 lay 2.9-fold (0.47 log units) below the measured number, and the stated range covers the measured number.
By their numbers in this assay, from the lowest: compounds 3 and 1 (each within the scatter of the next); then compound 4. At a limit, above all of these: compound 2.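

In this assay, among the compounds shown here, compound 4 brings an aromatic ring into this chain, which the earlier compounds did not have, and the value stays a measured number, with a 5.5-fold higher number from compound 3 to compound 4 (0.74 log units; beyond the scatter) and a 4.1-fold higher number from compound 1 to compound 4 (0.61 log units; beyond the scatter). Replacing but-3-en-1-yl with 4-cyanobenzyl on the oxygen on the aromatic ring therefore does not remove inhibition here, but it does cost a step beyond the scatter, against compounds 1 and 3 alike. The remaining comparison, an at least 1.3-fold lower number from compound 2 to compound 4 (0.13 log units; that floor lies within the scatter), is only a floor set by a limit and not by a number, so it fixes no size for that change: the limit of > 10000 nM in this assay, at which 1 of the 4 values shown sits.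

The compounds shown do not separate the nitrile from the benzyl ring that carries it, so a plain benzyl or a 4-methoxybenzyl on the same oxygen would be the direct test of which part accounts for the step. Also open, on these data alone, is how a chain ending in an amine or a carboxylic acid, or a longer chain, would read at this place.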